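A few compounds are considered here, and "the series" means these few. Any claim that something is new, unique, unknown or untested is made for them only; others in the source may bear on it.

Compound 1 `N=C(NCCCc1c[nH]cn1)NCCC(c1ccccc1)c1ccccn1` is a guanidine that carries a pyridin-2-yl group and a phenyl group on the same chain carbon. In a functional assay on cardiac atrium for agonist activity at histamine H2 receptor (Cavia porcellus) (a lower number here means a smaller maximal response, a higher number a larger maximal response), compound 1 gives 1, the highest of the two numbers recorded, and its nearest neighbour is compound 2 `N=C(NCCCc1c[nH]cn1)NCCC(c1ccc(C(F)(F)F)cc1)c1ccccn1`, which in this assay gives 0.9. For the measured compounds named here, the only step recorded, a number 0.10 lower from compound 1 to compound 2 (within the scatter), shows that adding trifluoromethyl on an aromatic carbon leaves the maximal response within the scatter.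

Compound 3 `N=C(NCCCc1c[nH]cn1)NCCC(c1ccccc1)c1ccc(F)cc1` differs from compound 1 as follows: 4-fluorophenyl in place of pyridin-2-yl on a saturated chain carbon bound to an aromatic carbon and a saturated chain carbon. Going by the values given here, no measured step exchanges one aromatic ring for another, so the step from compound 1 to compound 2 bears on it only loosely: it shows one change to the aromatic part that stayed within the scatter. On that basis no step beyond the scatter is expected, and the expected step is a number 0.10 lower from compound 1 to compound 3 (within the scatter). For compound 3 the intrinsic activity in this assay is therefore estimated at 0.9, within 0.7 to 1.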

Compound 3, intrinsic activity: the largest response reached, as a fraction of the reference agonist's: 1
Compound 3: middle estimate off by 0.10, on the low side; measured number inside the range.
By their numbers in this assay, from the lowest: compounds 2, 1 and 3 (each within the scatter of the next).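

Exchanging pyridin-2-yl for 4-fluorophenyl on a saturated chain carbon bound to an aromatic carbon and a saturated chain carbon gave no change at the digits printed from compound 1 to compound 3 (within the scatter) in this assay. The earlier step changed only a substituent on an aromatic carbon and kept pyridin-2-yl in place, whereas this one replaces that whole ring, so among these compounds a ring of carbon only, with 0 hydrogen-bond acceptors, serves in this position without a step beyond the scatter. No measurement at hand offers an explanation for this result.

The compounds shown leave open whether a non-aromatic group such as cyclohexyl, or a carboxylic acid, on this same chain carbon would keep the maximal response. Going by these compounds, they also give only the largest response reached, so how much of each compound is needed to reach it remains open.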